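Hydroxy Replaces Tert-Butyl on the Weakest Compound

The compounds below may be only part of what the source reports. "The series", "measured", "known", "first", "only" and "open" are said of these compounds alone.

Compound 3 `COc1ccc(CN2C(=O)C(=O)c3cc(-c4ccc(C(C)(C)C)cc4)ccc32)cc1` stands highest of the three compounds measured in a functional assay on HepG2 cells (Homo sapiens) for antiproliferative activity, read by MTT assay, with a stated time of 48 h (a higher number here means a weaker inhibitor, a lower number a stronger inhibitor), where compound 3 gives 4580 nM. Within the data shown here, compound 1 `COc1ccc(-c2ccc3c(c2)C(=O)C(=O)N3Cc2ccccc2OC)cc1` gives 130 nM and compound 2 `COc1ccc(-c2ccc3c(c2)C(=O)C(=O)N3Cc2ccc3ccccc3c2)cc1` gives 380 nM; the single step measured between them, a 2.9-fold higher number from compound 1 to compound 2 (0.47 log units; beyond the scatter), concerns the group on the saturated chain carbon bound to the amide-type nitrogen, not the place changed here. Compound 4 `COc1ccc(CN2C(=O)C(=O)c3cc(-c4ccc(O)cc4)ccc32)cc1` differs from compound 3 by hydroxy in place of tert-butyl on an aromatic carbon. Among the measured compounds shown here, no measured step bears on this exchange, so any expectation rests only on the wide gap between the value of compound 3 and those of compound 1 and compound 2. The number for compound 4 is expected to be lower, a step of a 6.5-fold lower number from compound 3 to compound 4 (0.82 log units; beyond the scatter). Compound 4 is estimated at 700 nM, within 150 nM to 3500 nM.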

Compound 4, half-maximal inhibitory concentration: > 10000 nM
Compound 4 gave a limit, no number; the forecaster's own chance of this, stated with the estimate: 5%; at least 14-fold (1.15 log units) between middle value and limit.
By their numbers in this assay, from the lowest: compound 1; then compound 2; then compound 3. At a limit, above all of these: compound 4.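

In this assay, hydroxy in place of tert-butyl on this aromatic carbon gives an at least 2.1-fold higher number from compound 3 to compound 4 (0.33 log units; beyond the scatter), so the exchange weakens an already weak compound further. This place therefore affects activity, and swapping the larger tert-butyl for hydroxy, which brings a hydrogen-bond donor, brings no gain here. Compound 4 gives only a limit, not a number, so the full size of the step stays unknown: the limit of > 10000 nM in this assay, at which 1 of the 4 values shown sits.

Going by these compounds, how an amine or a carboxylic acid would fare at this place remains open. So does whether hydroxy would have the same effect alongside the 2-methoxyphenyl group of compound 1.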